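Propyl for methoxycarbonyl in a series that shows only limits

This account rests on a few compounds, and the source may have more. Where it says the series, first, only, none or still open, it means among the compounds named here.

Of the compounds shown here, three have been measured in an assay on HEK293 cells for inhibition of N-acylethanolamine-hydrolyzing acid amidase (Rattus norvegicus), read by LC-MS, with a stated time of 30 min (a higher number here means a weaker inhibitor, a lower number a stronger inhibitor), and each result is a limit of the assay rather than a number.

Compound 1 `COC(=O)c1cccc(CCCCCCC(=O)N2CCCC2)c1` gives > 100000 nM.
Compound 2 `COC(=O)c1ccc(CCCCCCC(=O)N2CCCC2)cc1` gives > 100000 nM.
Compound 3 `CCCc1cccc(CCCCCCC(=O)N2CCCC2)c1` gives > 100000 nM.

The change from compound 1 to compound 3 is propyl in place of methoxycarbonyl on an aromatic carbon. Its step, a step that the two limits leave unreadable from compound 1 to compound 3, cannot be read because of the limit of > 100000 nM in this assay, at which 3 of the 3 values shown sit. The difference between the cores of compound 1 and compound 2 is not broken down here. Compound 4 `CCCc1ccc(CCCCCCC(=O)N2CCCC2)cc1` has not yet been measured; it differs from compound 2 by propyl in place of methoxycarbonyl on an aromatic carbon, the same kind of change as before, though here the place is para to a large group rather than meta to a large group. The expectation for it rests on compound 2, which itself gives only a limit, > 100000 nM. Compound 4 is therefore expected to give 150000 nM in this assay, somewhere between 50000 nM and 1000000 nM, which would mean an expected step that the limit leaves unreadable from compound 2 to compound 4.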

Compound 4, half-maximal inhibitory concentration: > 100000 nM
Compound 4: only a limit was reported; the forecaster's own chance of this, stated with the estimate: 90%; the middle value does not contradict the limit.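

No step can be read from compound 2 to compound 4, because both results are limits of the assay: the limit of > 100000 nM in this assay, at which 4 of the 4 values shown sit. The compounds shown leave open how strongly each inhibits the enzyme and whether propyl and methoxycarbonyl differ at all.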